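Replacing a fluorophenoxy with cyclohexylmethyl: expected solubility

This account rests on a few compounds, and the source may have more. Where it says the series, first, only, none or still open, it means among the compounds named here.

Compound 1, `COc1cccc(CNCCCNc2ccnc3cc(Cc4cc(C)cc(C)c4)ccc23)c1O`, gives 4200 nM in a physicochemical assay for solubility, with a stated time of 18 h, at pH 7.4; on this read-out lower numbers stand for lower solubility and higher numbers for higher solubility.
Compound 2, `COc1ccc(Oc2ccc3c(NCCCNCc4cccc(OC)c4O)ccnc3c2)cc1`, gives 14500 nM in this assay.
Compound 3, `COc1cccc(CNCCCNc2ccnc3cc(Oc4ccc(F)cc4)ccc23)c1O`, gives 14500 nM in this assay.

Compound 3 stands level with compound 2 at the digits printed, and together they hold the highest of the three numbers; the step of no change at the digits printed from compound 2 to compound 3 (within the scatter) is within the scatter. Compound 1 is the furthest from compound 3, with a 3.5-fold higher number from compound 1 to compound 3 (0.54 log units; beyond the scatter); the parallel step a 3.5-fold higher number from compound 1 to compound 2 (0.54 log units; beyond the scatter) is of the same size.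

Compound 4, `COc1cccc(CNCCCNc2ccnc3cc(CC4CCCCC4)ccc23)c1O`, has not yet been measured. (cyclohexylmethyl in place of 4-fluorophenoxy on an aromatic carbon). For the measured compounds named here, the one measured step that bears on this is the reverse kind of exchange: going from compound 1 to compound 3, a 3,5-dimethylbenzyl group left and a 4-fluorophenoxy group entered, and the number rose by a 3.5-fold higher number from compound 1 to compound 3 (0.54 log units; beyond the scatter). In compound 4 the phenoxy group leaves again and a cyclohexylmethyl enters, so a drop of similar size is expected, roughly back toward the level of compound 1. The expected step is a 3.2-fold lower number from compound 3 to compound 4 (0.51 log units; beyond the scatter). Compound 4 is therefore estimated at 4500 nM in this assay, with a range from 1500 nM to 13000 nM.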

Compound 4, solubility: 4200 nM
Estimate against measurement, compound 4: 1.1-fold (0.03 log units) above, and the stated range covers the measured number.
By their numbers in this assay, from the lowest: compounds 1 and 4 (each within the scatter of the next); then compounds 2 and 3 (each within the scatter of the next).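

Putting cyclohexylmethyl in place of 4-fluorophenoxy on this aromatic carbon gives a 3.5-fold lower number from compound 3 to compound 4 (0.54 log units; beyond the scatter) in this assay, and putting it in place of 4-methoxyphenoxy gives a 3.5-fold lower number from compound 2 to compound 4 (0.54 log units; beyond the scatter) on the same read-out. Cyclohexyl in place of 3,5-dimethylphenyl on the saturated chain carbon gives no change at the digits printed from compound 1 to compound 4 (within the scatter) here, so within this pair, exchanging an aromatic ring for a non-aromatic one leaves the number unchanged. Across all four compounds, with none going against it, the two groups joined to the core through oxygen share the higher level and the two joined through carbon share the lower level, a split that a single benzyl example could only hint at.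

Each step between the two levels changes the linking atom and the ring at once, so a cyclohexyloxy group, compared with the cyclohexylmethyl of compound 4, would be needed to show whether the linking oxygen alone accounts for the split. No measurement shown here offers an explanation for these differences.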